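A few compounds are considered here, and "the series" means these few. Any claim that something is new, unique, unknown or untested is made for them only; others in the source may bear on it.

The three measured compounds share one core and differ only in the aromatic ring attached to it. Compound 1 `O=C(NCCCCc1ccccc1)n1cc(-c2ccc(F)cc2)oc1=O` gives 185 nM in an assay on isolated protein for inhibition of acid ceramidase (Homo sapiens), read by LC-MS, with a stated time of 1 h; a higher number here means a weaker inhibitor, a lower number a stronger inhibitor. Compound 2 `COc1cc(-c2cn(C(=O)NCCCCc3ccccc3)c(=O)o2)ccc1F` gives 80 nM in this assay, and compound 3 `CN1CCC(c2cccc(-c3cn(C(=O)NCCCCc4ccccc4)c(=O)o3)c2)CC1` gives 153 nM. On these numbers compound 3 stands second highest of the three: its nearest neighbour is compound 1, within the scatter, and compound 2 lies furthest from it, also within the scatter. Compound 4 `CN1CCC(c2cc(-c3cn(C(=O)NCCCCc4ccccc4)c(=O)o3)ccc2F)CC1` differs from compound 3 by fluoro in place of hydrogen on an aromatic carbon. Among the compounds with values here, the only single-site step known here is a 2.3-fold lower number from compound 1 to compound 2 (0.36 log units; beyond the scatter), which put a small group onto the aromatic ring and moved the number modestly. The change into compound 4 likewise adds one small group to that ring, so a step of similar or smaller size is expected, with the direction uncertain. The estimated step is a 1.5-fold lower number from compound 3 to compound 4 (0.16 log units; within the scatter). Compound 4 is therefore expected to give 105 nM, within a range from 45 nM to 240 nM.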

Compound 4, half-maximal inhibitory concentration in the acid ceramidase assay: 341 nM
Estimate against measurement, compound 4: 3.2-fold (0.51 log units) below; the measured number lies above the stated range.
By their numbers in the acid ceramidase assay, from the lowest: compounds 2, 3, 1 and 4 (each within the scatter of the next, the first and the last beyond it).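

In the acid ceramidase assay, fluoro in place of hydrogen ortho to a 1-methylpiperidin-4-yl group gives a 2.2-fold higher number from compound 3 to compound 4 (0.35 log units; beyond the scatter), so a single added atom on this ring can move the number up, whereas the earlier methoxy step moved it down. With the fluoro present in both compounds, the acid ceramidase assay shows 1-methylpiperidin-4-yl in place of methoxy as a 4.3-fold higher number from compound 2 to compound 4 (0.63 log units; beyond the scatter), while the same group in place of hydrogen gives a 1.8-fold higher number from compound 1 to compound 4 (0.27 log units; within the scatter), so only the methoxy comparison exceeds the scatter. In a physicochemical assay for solubility, read by HPLC, in phosphate buffer, measured as kinetic solubility, with a stated time of 1 h, at pH 7.4, tested at 250 uM (a lower number here means a less soluble compound, a higher number a more soluble compound), compound 3 gives 70000 nM and compound 4 gives 30000 nM. The same fluoro change also comes with a lower number in the physicochemical assay: the measured solubility of compound 3, 70000 nM, and of compound 4, 30000 nM, a 2.3-fold lower number (0.37 log units; beyond the scatter)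

On these data alone, whether chloro at this place would follow fluoro remains open, as does whether the step would hold with morpholin-4-yl in place of 1-methylpiperidin-4-yl. Whether the two shifts are linked cannot be told from one pair.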